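A few compounds are considered here, and "the series" means these few. Any claim that something is new, unique, unknown or untested is made for them only; others in the source may bear on it.

Measured so far in a functional assay on CEM-SS cells (Homo sapiens) for cytotoxicity; a lower number here means a stronger inhibitor, a higher number a weaker inhibitor:

- Compound 1 `Nc1nc2cc(Cl)c(Cl)cc2n1Cc1cccc(Cl)c1`: 37000 nM
- Compound 2 `Cc1cccc(Cn2c(N)nc3cc(Cl)c(Cl)cc32)c1`: 48000 nM
- Compound 3 `Nc1nc2cc(Cl)c(Cl)cc2n1Cc1cccc(C(F)(F)F)c1`: 34000 nM

These three compounds share a core and differ only in one group on an aromatic carbon. Compound 3, at 34000 nM, cannot be ranked against the other two, since its numbers sit within the ordinary scatter of both.

The next structure is compound 4 `Nc1nc2cc(Cl)c(Cl)cc2n1Cc1cccc([N+](=O)[O-])c1`, which differs from compound 3 by one exchange: nitro in place of trifluoromethyl on an aromatic carbon. Put simply, it carries nitro in place of trifluoromethyl on an aromatic carbon.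

For the measured compounds named here, three measured steps bear on this change, all at the same place. Methyl in place of chloro gave a 1.3-fold higher number from compound 1 to compound 2 (0.11 log units; within the scatter). Trifluoromethyl in place of chloro gave a 1.1-fold lower number from compound 1 to compound 3 (0.04 log units; within the scatter). Trifluoromethyl in place of methyl gave a 1.4-fold lower number from compound 2 to compound 3 (0.15 log units; within the scatter). Going by the values given here, none of the three stands out from the scatter, and no compound so far goes against this flat picture. Among the compounds with values here, no nitro compound has been measured yet, so the evidence is indirect and the range must stay fairly wide.

The expected result is therefore no real change in this assay, with an estimated 1.1-fold higher number from compound 3 to compound 4 (0.02 log units; within the scatter). For compound 4 the estimated value is 36000 nM, with an expected range from 18000 nM to 65000 nM.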

Compound 4, half-maximal inhibitory concentration: 47000 nM
For compound 4 the middle estimate is 1.3-fold (0.12 log units) below the measured one; the measured number falls inside the stated range.
By their numbers in this assay, from the lowest: compounds 3, 1, 4 and 2 (each within the scatter of the next).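

In this assay, nitro behaves like the three groups already seen at this position, and none of its exchanges moves the number beyond the usual scatter: replacing trifluoromethyl gives little change (a 1.4-fold higher number from compound 3 to compound 4 (0.14 log units; within the scatter)), as does replacing methyl (a 1.0-fold lower number from compound 2 to compound 4 (0.01 log units; within the scatter)) or chloro (a 1.3-fold higher number from compound 1 to compound 4 (0.10 log units; within the scatter)). The new exchange brings nitrogen and oxygen into the group, and the count of hydrogen-bond acceptors goes from 0 to 2. The four compounds still cannot be ranked. Nothing available here explains this flat result, so it stands only as an observation.

All four compounds carry their varied group at the same place on the same ring, so they leave open whether a group on another carbon of that ring would behave the same way. They also leave open whether a more different group at this position, such as a carboxylic acid, an amine or a longer chain, would move the number beyond the scatter.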